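Sulfonamide nitrogen substitution in the butylpyridinone tetrazole series

The source may hold more compounds than are shown below. What is called first, only, known or untested is meant among the compounds shown, and "the series" means these compounds.

Measured in a functional assay (aorta) for antagonist activity, with Oryctolagus cuniculus as the target; on this read-out higher numbers stand for weaker inhibition and lower numbers for stronger inhibition:
compound 1 `CCCCc1ccc(CNC(=O)OC(C)(C)C)c(=O)n1Cc1ccc(-c2ccccc2-c2nn[nH]n2)cc1`: 10 nM
compound 2 `CCCCc1ccc(CNC(=O)NC2CCCCC2)c(=O)n1Cc1ccc(-c2ccccc2-c2nn[nH]n2)cc1`: 90 nM
compound 3 `CCCCc1ccc(CNS(C)(=O)=O)c(=O)n1Cc1ccc(-c2ccccc2-c2nn[nH]n2)cc1`: 2 nM

Compound 3 holds the lowest number of the three, the step being a 5.0-fold lower number from compound 1 to compound 3 (0.70 log units; beyond the scatter) and a 45-fold lower number from compound 2 to compound 3 (1.65 log units; beyond the scatter); between the two carbamate-type analogues the step was a 9.0-fold higher number from compound 1 to compound 2 (0.95 log units; beyond the scatter). Compound 4 `CCCCc1ccc(CN(C(C)C)S(C)(=O)=O)c(=O)n1Cc1ccc(-c2ccccc2-c2nn[nH]n2)cc1` differs from compound 3 by isopropyl in place of hydrogen on a sulfonamide nitrogen. Among the measured compounds shown here, none of the measured steps touches the hydrogen on that nitrogen; each of them exchanges the group on the carbonyl or sulfonyl side, so no step in this assay bears directly on the change. For the measured compounds named here, with no precedent, the expectation for compound 4 is a step of at most modest size in this assay, direction uncertain, leaning towards a higher number. Compound 4 is estimated at 6 nM, range 1.5 nM to 25 nM, meaning a 3.0-fold higher number from compound 3 to compound 4 (0.48 log units; beyond the scatter).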

Compound 4, half-maximal inhibitory concentration: 0.9 nM
The estimate for compound 4 lay 6.7-fold (0.82 log units) above the measured number; measured number below the stated range.
By their numbers in this assay, from the lowest: compound 4; then compound 3; then compound 1; then compound 2.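

In this assay the sulfonamide nitrogen accepts isopropyl in place of hydrogen without loss (step: a 2.2-fold lower number from compound 3 to compound 4 (0.35 log units; beyond the scatter)), so that hydrogen is not required for a low number here. Compound 4 holds the lowest number of the four, with steps of an 11-fold lower number from compound 1 to compound 4 (1.05 log units; beyond the scatter) and a 100-fold lower number from compound 2 to compound 4 (2.00 log units; beyond the scatter). No evidence at hand explains this result. From the compounds shown here alone, whether a methyl group, a longer chain such as n-butyl or a cyclopentyl ring on that nitrogen keeps the number this low stays open. So does whether the methylsulfonyl group can give way to phenylsulfonyl with isopropyl in place.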